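Compound 3 to Compound 4: An Expected Solubility Step

The source may hold more compounds than are shown below. What is called first, only, known or untested is meant among the compounds shown, and "the series" means these compounds.

Of the compounds shown here, three have been measured in a physicochemical assay for solubility, in phosphate buffer, measured as kinetic solubility, with a stated time of 1 h, at pH 7.4; on this read-out higher numbers stand for higher solubility and lower numbers for lower solubility. Compound 1 `Cc1cc(C)cc(NC(=O)COc2cc(C)nc3ccc(F)cc23)c1` gives 28000 nM, compound 2 `COc1ccc2nc(C)cc(NC(=O)C(=O)Nc3cc(C)cc(C)c3)c2c1` gives 10000 nM, and compound 3 `COc1ccc(NC(=O)COc2cc(C)nc3ccc(OC)cc23)cc1` gives 108000 nM. Compound 3 therefore stands highest of the three numbers, with compound 1 nearest below it and compound 2 furthest below it, both gaps lying beyond the usual scatter. Among the compounds with values here, no two of the measured compounds differ in only one place, so no measured step is available to lean on.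

Compound 4 `COc1ccc2nc(C)cc(OCC(=O)Nc3cccnc3)c2c1` has not yet been measured. It differs from compound 3 by pyridin-3-yl in place of 4-methoxyphenyl on an amide-type nitrogen, a pyridin-3-yl in place of 4-methoxyphenyl on an amide-type nitrogen whose other neighbour is the carbonyl carbon. Without a measured step of this kind, the account expects a modest upward step in this assay, one that may still fall within the scatter. The expected step is a 1.5-fold higher number from compound 3 to compound 4 (0.17 log units; within the scatter). Compound 4 is accordingly estimated at 160000 nM, with a range from 60000 nM to 400000 nM.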

Compound 4, solubility: 32000 nM
Estimate against measurement, compound 4: 5.0-fold (0.70 log units) above; measured number below the stated range.
By their numbers in this assay, from the lowest: compound 2; then compounds 1 and 4 (each within the scatter of the next); then compound 3.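

In this assay, pyridin-3-yl in place of 4-methoxyphenyl on an amide-type nitrogen whose other neighbour is the carbonyl carbon gives a 3.4-fold lower number from compound 3 to compound 4 (0.53 log units; beyond the scatter), the first measured step among these compounds that differ in one place. It shows that the group at this place on the nitrogen can move the read-out beyond the scatter, and that here the ring with a hetero atom goes with the lower number. Nothing on hand accounts for the size or direction of this step.

The single step exchanges the methoxy group and a ring carbon for nitrogen together, and the compounds shown do not separate the two. They also leave open how an unsubstituted phenyl, or a pyridin-3-yl carrying a morpholine, would read at this place.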